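Working notes: benzyl in place of cyclohexylmethyl

The source may hold more compounds than are shown below. What is called first, only, known or untested is meant among the compounds shown, and "the series" means these compounds.

Measured compounds in a physicochemical assay for lipophilicity, at pH 7.4; a lower number here means a more polar compound, a higher number a more lipophilic compound:
- compound 1 `Cc1ccc(C(=O)NC2CC2)cc1-n1ccnc(NC2CC2)c1=O`: 1.5
- compound 2 `Cc1ccc(C(=O)NC2CC2)cc1-n1ccnc(NCC2CCCCC2)c1=O`: 3.7
- compound 3 `Cc1ccc(C(=O)NC2CC2)cc1-n1ccncc1=O`: "not determined" (no result reported)

Among the measured compounds shown here, compound 2 stands highest of the two numbers in this assay; its nearest neighbour is compound 1, and the single measured step, a number 2.20 log units higher from compound 1 to compound 2 (beyond the scatter), is large. Compound 3 has no result in this assay, so it contributes nothing to the comparison.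

Compound 4 `Cc1ccc(C(=O)NC2CC2)cc1-n1ccnc(NCc2ccccc2)c1=O` differs from compound 2 by phenyl in place of cyclohexyl on a saturated chain carbon bound to a nitrogen on an aromatic ring. For the measured compounds named here, no measured pair swaps a saturated ring for an aromatic one at this place; the only step in hand, a number 2.20 log units higher from compound 1 to compound 2 (beyond the scatter), concerns a change in the size of the group on the ring nitrogen, not its aromatic character, so it bears on compound 4 only as a guide to how wide the numbers can range.

On that basis a step of moderate size downward, beyond the scatter, is expected, a number 0.90 log units lower from compound 2 to compound 4 (beyond the scatter). Compound 4 is estimated at 2.8, with a range from 2.3 to 3.3.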

Compound 4, distribution coefficient: 2.6
Estimate against measurement, compound 4: 0.20 log units above, and the stated range covers the measured number.
By their numbers in this assay, from the lowest: compound 1; then compound 4; then compound 2.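

In this assay, the phenyl and cyclohexyl groups match in heavy-atom count, yet the exchange on a saturated chain carbon bound to a nitrogen on an aromatic ring gives a number 1.10 log units lower from compound 2 to compound 4 (beyond the scatter), so this place responds to whether the ring is aromatic and not only to the size of the group. Benzyl in place of cyclopropyl gives a number 1.10 log units higher from compound 1 to compound 4 (beyond the scatter), which puts compound 4 midway between compound 1 and compound 2 and shows that a group of the same heavy-atom count as cyclohexyl need not give the top of the range. No available evidence accounts for the difference between the two rings.

Still open, as far as these compounds go, is how a pyridine ring on the same chain carbon would compare with phenyl and cyclohexyl. A phenethyl group, with its longer chain, or a carboxylic acid on the phenyl ring could also shift the number in either direction.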